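A few compounds are considered here, and "the series" means these few. Any claim that something is new, unique, unknown or untested is made for them only; others in the source may bear on it.

Compound 1 `Clc1ccc(NC2=NCCC3(CCCCC3)S2)cc1` is a member of a small pair of thiazine-type amidines sharing a spirocyclic core. In a physicochemical assay for lipophilicity, measured as octanol-water partition, at pH 7.4 (on this read-out lower numbers stand for lower lipophilicity and higher numbers for higher lipophilicity), compound 1 gives 2.5, the higher of the two values measured. Its neighbour, compound 2 `NC1=NCCC2(CCCCC2)S1`, in which the anilino group is replaced by a free amino group, gives in this assay 1.57, a number that sits well below compound 1 and beyond the usual scatter.

The next compound, compound 3 `Cc1ccc(NC2=NCCC3(CCCCC3)S2)cc1`, differs from compound 1 in a single place: methyl in place of chloro on an aromatic carbon. Among the measured compounds shown here, because the measured values of compound 1 2.5 and compound 2 1.57 span only a change at the amidine nitrogen, no measured step speaks directly to this exchange. The step of a number 0.20 log units lower from compound 1 to compound 3 (within the scatter) from compound 1 to compound 3 is expected to be small, downward, and probably within the scatter. Compound 3 is therefore estimated at 2.3, with a range from 1.9 to 2.7.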

Compound 3, distribution coefficient: 1.56
For compound 3 the middle estimate is 0.74 log units above the measured one; measured number outside the range, below it.
By their numbers in this assay, from the lowest: compounds 3 and 2 (each within the scatter of the next); then compound 1.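

In this assay, among the compounds shown here, the exchange of chloro for methyl on this aromatic carbon, para to a large group, gives the first measured single-place step on the aromatic ring, and that step is clear: a number 0.94 log units lower from compound 1 to compound 3 (beyond the scatter). This position therefore separates two groups of one heavy atom each, neither with a hydrogen-bond donor or acceptor, by more than the scatter. Nothing available accounts for the size of this step.

With only chloro and methyl shown on this carbon, the compounds leave open how a bromo group, a methoxy group or a carboxylic acid would read there. Also open, as far as these compounds go, is whether the same exchange would give a step of this size at another carbon of the aromatic ring.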